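Dichloro substitution on the fused core: myeloma growth inhibition notes

This account rests on a few compounds, and the source may have more. Where it says the series, first, only, none or still open, it means among the compounds named here.

Compound 1 `ClCc1cccc(Cn2cnc3c(Cl)ncnc32)c1` and compound 3 `ClCc1ccccc1Cn1cnc2ncnc(Cl)c21` share the same atoms joined differently; the difference between the two cores is not broken down here. In a functional assay on RPMI-8226 cells (Homo sapiens) for cytotoxicity, read by sulforhodamine B assay, with a stated time of 48 h (on this read-out higher numbers stand for weaker inhibition of growth and lower numbers for stronger inhibition of growth), compound 1 gives 16200 nM, while compound 3 gives 5490 nM. Compound 2 `ClCc1cccc(Cn2cnc3c(Cl)nc(Cl)nc32)c1` carries chloro in place of hydrogen on an aromatic carbon and in this assay reaches only the limit > 100000 nM, a limit rather than a number. The step of an at least 6.1-fold higher number from compound 1 to compound 2 (0.79 log units; beyond the scatter) is therefore bounded by the limit (the limit of > 100000 nM in this assay, at which 1 of the 3 values shown sits). Compound 4 `ClCc1ccccc1Cn1cnc2nc(Cl)nc(Cl)c21` differs from compound 3 by chloro in place of hydrogen on an aromatic carbon, the same change made on the other core. Applied to compound 3, the expected step is a 7.3-fold higher number from compound 3 to compound 4 (0.86 log units; beyond the scatter), resting on the step of an at least 6.1-fold higher number from compound 1 to compound 2 (0.79 log units; beyond the scatter). For compound 4 the estimated value in this assay is 40000 nM, expected between 12000 nM and 100000 nM, with a real chance of a limit.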

Compound 4, concentration for total growth inhibition: 630 nM
The estimate for compound 4 lay 63-fold (1.80 log units) above the measured number, and the stated range ends above it.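

In this assay, chloro in place of hydrogen on an aromatic carbon gives an 8.7-fold lower number from compound 3 to compound 4 (0.94 log units; beyond the scatter), so on these two cores the same change does not carry over in the same direction: the same change on two cores in this assay, an at least 6.1-fold higher number (0.79 log units; beyond the scatter) from compound 1 to compound 2 and an 8.7-fold lower number (0.94 log units; beyond the scatter) from compound 3 to compound 4, at least 53-fold (1.73 log units) apart, beyond the scatter of two such steps. The earlier step is bounded by a limit rather than a number: the limit of > 100000 nM in this assay, at which 1 of the 4 values shown sits. These two pairs do not show which difference between the cores accounts for the divergence, and they give no rule for a third core or for another group at this place.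

On these data alone, it remains open whether an amine or a methoxy group at this place, between two ring nitrogen atoms, would diverge in the same way on the two cores. As far as these compounds go, the effect of replacing the chloromethyl group with a longer chain also remains open.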